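The compounds below may be only part of what the source reports. "The series", "measured", "known", "first", "only" and "open" are said of these compounds alone.

Working notes on the series. Within the data shown here, compound 1 `O=C1CC(c2c(-c3ccc[nH]3)[nH]c3ccccc23)C(=O)N1` is the strongest of the three measured members: in a functional assay on U-373MG ATCC cells (Homo sapiens) for cytotoxicity, read by MTT assay, with a stated time of 72 h (a lower number here means a stronger inhibitor, a higher number a weaker inhibitor), compound 1 gives 4000 nM. Compound 3 `O=C1NC(=O)C(c2c(-n3cccn3)[nH]c3ccccc23)=C1Br` gives 27000 nM in this assay, and compound 2 `Cc1ccc2[nH]c(-n3cccn3)c(C3=C(Br)C(=O)NC3=O)c2c1` gives 27000 nM. The two share a core that differs from the core of compound 1; that difference is not broken down here. Between them the single change methyl in place of hydrogen on an aromatic carbon produced no change at the digits printed from compound 3 to compound 2 (within the scatter). Compound 4 `Cc1ccc2[nH]c(-c3ccc[nH]3)c(C3CC(=O)NC3=O)c2c1` is not yet measured; it differs from compound 1 by methyl in place of hydrogen on an aromatic carbon, the same change that separates compound 2 from compound 3. The step from compound 1 to compound 4 in this assay is therefore expected to be about as flat, no change at the digits printed from compound 1 to compound 4 (within the scatter), because no change at the digits printed from compound 3 to compound 2 (within the scatter) showed the change to be neutral on the other core. Compound 4 is estimated at 4000 nM, expected between 2000 nM and 10000 nM.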

Compound 4, half-maximal inhibitory concentration: 5000 nM
Compound 4: middle estimate off by 1.3-fold (0.10 log units), on the low side; the range from low to high includes it.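

Methyl in place of hydrogen on an aromatic carbon gives a 1.3-fold higher number from compound 1 to compound 4 (0.10 log units; within the scatter) in this assay, so the change is also neutral on the core of compound 1. The two steps agree: the same change on two cores in this assay, no change at the digits printed (within the scatter) from compound 3 to compound 2 and a 1.3-fold higher number (0.10 log units; within the scatter) from compound 1 to compound 4, 1.3-fold (0.10 log units) apart, within the scatter of two such steps. This supports carrying this one change between these two cores in this assay, but it rests on one matched pair per core and one position, and it does not show that the change would transfer to other cores or cell lines.

From the compounds shown here alone, whether an amine, a carboxylic acid or a longer chain at that place would be as neutral remains open. The core of compound 1 and the core of compound 3 differ in more than one place, and the compounds shown do not separate those differences.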